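The source may hold more compounds than are shown below. What is called first, only, known or untested is meant among the compounds shown, and "the series" means these compounds.

In a functional assay on HEK293 cells for agonist activity at G-protein coupled receptor 39 (Homo sapiens), read by scintillation proximity assay and inositol phosphate accumulation, with a stated time of 75 min (a higher number here means that more compound is needed for the effect, a lower number that less compound is needed), compound 3 `Cc1nn(-c2ncnc3nc[nH]c23)c2c1C(OCc1ccccc1F)CC(=O)N2` gives 78 nM, the lowest of the three numbers measured. Compound 1 `Cc1nn(-c2ncnc3nc[nH]c23)c2c1C(OCC(=O)c1ccc(F)cc1)CC(=O)N2` gives 973 nM, and compound 2 `Cc1nn(-c2ncnc3nc[nH]c23)c2c1C(C(=O)NCc1ccc(F)cc1)CC(=O)N2` gives 1220 nM; both lie well above compound 3 in this assay. Among the compounds with values here, the one step measured within this set that changes only one place, a 12-fold lower number from compound 1 to compound 3 (1.10 log units; beyond the scatter), shows that the group hanging from the oxygen on the saturated carbon of the shared core matters a great deal.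

Compound 4 `CCCCCCCCOC1CC(=O)Nc2c1c(C)nn2-c1ncnc2nc[nH]c12` keeps that oxygen but changes what sits on it: heptyl in place of 2-fluorophenyl on a saturated chain carbon bound to an oxygen on a saturated carbon. The measured steps give no direct guide for swapping a fluorinated aromatic ring for an open carbon chain of the same heavy-atom count; the step from compound 1 to compound 3 only shows that this position is sensitive. Since the two stronger side chains in this assay were both aromatic, a move to a plain chain is expected to cost potency, and compound 4 is expected to show a step of a 5.8-fold higher number from compound 3 to compound 4 (0.76 log units; beyond the scatter), toward a higher number, though with wide uncertainty. Compound 4 is thus estimated at 450 nM in this assay, within a range from 80 nM to 2500 nM.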

Compound 4, half-maximal effective concentration: 388 nM
Estimate against measurement, compound 4: 1.2-fold (0.06 log units) above; measured number inside the range.
By their numbers in this assay, from the lowest: compound 3; then compound 4; then compounds 1 and 2 (each within the scatter of the next).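

The heptyl change shows that this position does not need an aromatic ring to give a measurable effect in this assay: an open carbon chain on the oxygen stays active, although a 5.0-fold higher number from compound 3 to compound 4 (0.70 log units; beyond the scatter) shows that it does not match the 2-fluorophenyl group. Having an aromatic ring on the side chain is also not enough on its own to give a low number, as a 2.5-fold lower number from compound 1 to compound 4 (0.40 log units; beyond the scatter) favours the ringless chain of compound 4 over the ring-bearing (4-fluorophenyl)carbonyl side chain of compound 1, so among these three compounds the order depends on more than the presence of a ring. No measurement at hand explains what lies behind these differences.

The compounds shown leave open whether the fluorine of compound 3 counts for anything, which a plain benzyl group on the oxygen would test, and how the number moves with chain length, which a shorter butyl chain or a longer decyl chain in place of octyl would test. They also leave open what a chain ending in an amine or a carboxylic acid would give at this place.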